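From trifluoromethyl to ethoxycarbonyl on the shared core

The source may report more compounds than this note shows. Statements on the series, on what has been measured and on what is new or still open speak of the compounds shown alone.

Measured in an ADME assay on HaCaT cells (Homo sapiens) for antiproliferative activity, with a stated time of 48 h; a higher number here means a weaker inhibitor, a lower number a stronger inhibitor:
Compound 1 `CCN(CC)c1ccc(-c2cccc(OC)c2)nn1`: > 25000 nM (a limit)
Compound 2 `CCN(CC)c1ccc(-c2cccc(C(F)(F)F)c2)nn1`: > 25000 nM (a limit)
Compound 3 `CCN(CC)c1ccc(-c2ccc(C(=O)OC)cc2)nn1`: 80 nM

Compound 2 stands at > 25000 nM, which is a limit and not a number. The only other limit shown belongs to compound 1, at > 25000 nM. Within the data shown here, in the series so far, the picture is this: the limit of > 25000 nM in this assay, at which 2 of the 3 values shown sit.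

Compound 4 `CCOC(=O)c1cccc(-c2ccc(N(CC)CC)nn2)c1` replaces the trifluoromethyl of compound 2 with ethoxycarbonyl on an aromatic carbon, meta to a large group: ethoxycarbonyl in place of trifluoromethyl on an aromatic carbon.

Among the measured compounds shown here, only one measured step bears directly on this place, and it is a step that the two limits leave unreadable from compound 1 to compound 2. It therefore gives no size to carry over. For the measured compounds named here, the sole numeric reading comes from compound 3, which gives 80 nM in this assay and also carries an ester, though at a different place and with a different chain. Compound 4 is therefore expected to move toward a stronger inhibitor, but only partly toward compound 3, and it may well stay at the limit. The expected change is an at least 3.1-fold lower number from compound 2 to compound 4 (0.49 log units; beyond the scatter). For compound 4 the estimated value is 8000 nM, with an expected range from 500 nM to 25000 nM.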

Compound 4, half-maximal inhibitory concentration: > 25000 nM
Compound 4: a limit, no number (the forecaster's own chance of this, stated with the estimate: 45%); at least 3.1-fold (0.49 log units) between middle value and limit.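

In this assay compound 4 gives > 25000 nM, which is a limit and not a number, so the steps to it from compound 1 and from compound 2, both also limits, cannot be read. The compounds shown leave open how methoxy, trifluoromethyl and ethoxycarbonyl rank at this place, since none of the three yields a number.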